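The source may hold more compounds than are shown below. What is called first, only, known or untested is meant among the compounds shown, and "the series" means these compounds.

Working notes on the series. Compound 1 `CC(Oc1ccc(N2C(N)=NC(N)=NC2(C)C)cc1Cl)C(=O)Nc1ccc(S(=O)(=O)F)cc1` in an assay on isolated protein for inhibition of Dihydrofolate reductase (Mus musculus) (a lower number here means a less potent compound, a higher number a more potent compound, by a factor of ten per unit of this negative logarithm), gives 7.13. Compound 2 `CC1(C)N=C(N)N=C(N)N1c1ccc(OCCCNC(=O)Nc2cccc(S(=O)(=O)F)c2)cc1` gives 7.32 in this assay, the second highest of the three numbers; compound 1 lies within the scatter of it. Compound 3 `CC1(C)N=C(N)N=C(N)N1c1ccc(OCc2c(Cl)cccc2S(=O)(=O)F)c(Cl)c1` gives 7.72 in this assay, a number higher than that of compound 2 by more than the scatter. Among the measured compounds shown here, no two of the measured compounds differ in one place only, so no single step is known.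

Compound 4 `CC1(C)N=C(N)N=C(N)N1c1ccc(OCCCNC(=O)Nc2cccc(S(=O)(=O)F)c2)c(Cl)c1` has not yet been measured in this assay. It differs from compound 2 as follows: chloro in place of hydrogen on an aromatic carbon. Compound 1 and compound 3 also carry a chloro group, but each differs from compound 2 in further ways, so nothing measured fixes this step. The step from compound 2 to compound 4 is expected to be small and toward a higher number, about a number 0.18 log units higher from compound 2 to compound 4 (within the scatter), not clearly beyond the scatter. Compound 4 is therefore estimated at 7.5 in this assay, with a range from 7 to 8.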

Compound 4, logarithm of the reciprocal of the active concentration, log(1/C): 7.28
Estimate against measurement, compound 4: 0.22 log units above; low and high end bracket the measured number.
By their numbers in this assay, from the lowest: compounds 1, 4 and 2 (each within the scatter of the next); then compound 3.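

In this assay, chloro in place of hydrogen on an aromatic carbon, ortho to a large group and meta to a large group, gives a number 0.04 log units lower from compound 2 to compound 4 (within the scatter), so the two numbers cannot be told apart at this position on this chain. Among the compounds shown here, this is the first single step; compound 1 and compound 3 also carry chloro, but they differ from compound 2 in further ways and could not isolate it. Nothing measured on these compounds gives a reason for this result.

As far as these compounds go, whether a methyl, a methoxy or a fluoro group at this same position would also leave the number within the scatter remains open. Also open, from the compounds shown here alone, is whether the chloro step would read the same on a longer chain or on the linking chains of compound 1 and compound 3.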